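Compound 2 and a new side chain on the nitrogen

A few compounds are considered here, and "the series" means these few. Any claim that something is new, unique, unknown or untested is made for them only; others in the source may bear on it.

- compound 1 (`CCOc1nc(-c2ccc(Cl)cc2Cl)c(CC)nc1NC(CC)CC`): 2 h
- compound 2 (`CCc1nc(-c2ccc(Cl)cc2Cl)c(CC)nc1NC(C1CC1)C1CC1`): 0.183 h

In an in vitro ADME assay on microsomes (Homo sapiens) for metabolic stability (a higher number here means that the compound lasts longer, a lower number that the compound disappears faster), compound 2 stands lowest of the two at 0.183 h and compound 1 lies well above it, a gap beyond the usual scatter. Compound 3 (`CCc1nc(-c2ccc(Cl)cc2Cl)c(CC)nc1NC(C)CN(C)C`) differs from compound 2 in one place: 1-((dimethylamino)methyl)ethyl in place of dicyclopropylmethyl on a nitrogen on an aromatic ring with 1-((dimethylamino)methyl)ethyl in place of dicyclopropylmethyl on a nitrogen on an aromatic ring. Going by the values given here, no measured pair shows this change. Among the compounds with values here, with compound 2 at 0.183 h and compound 1 at 2 h as the only guides, a moderate upward step is expected in this assay and it should land between those two values. The expected step is a 2.7-fold higher number from compound 2 to compound 3 (0.44 log units; beyond the scatter) and it carries much uncertainty. The estimated half-life for compound 3 is 0.5 h (expected range 0.15 h to 1.8 h).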

Compound 3, half-life: 0.117 h
Compound 3: middle estimate off by 4.3-fold (0.63 log units), on the high side; measured number below the stated range.
By their numbers in this assay, from the lowest: compounds 3 and 2 (each within the scatter of the next); then compound 1.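

In this assay, putting 1-((dimethylamino)methyl)ethyl in place of dicyclopropylmethyl on a nitrogen on an aromatic ring gives a 1.6-fold lower number from compound 2 to compound 3 (0.19 log units; within the scatter) and so leaves the two compounds indistinguishable. A side chain with no ring and one extra nitrogen therefore reads the same here as one carrying two three-membered rings of carbon. Nothing available explains this result at this position. Still open, on these data alone, is whether a different group on this nitrogen, such as a morpholine ring or a longer chain ending in a carboxylic acid, would shift the half-life beyond the scatter.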